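Shortening an ester chain: from ethyl to methyl

This account rests on a few compounds, and the source may have more. Where it says the series, first, only, none or still open, it means among the compounds named here.

Compound 1 `CCOC(=O)C1C(=O)C=C(Nc2cccc(N3CCN(C)CC3)c2)CC1c1ccccc1`: 4.37
Compound 2 `COC(=O)C1C(=O)C=C(Nc2ccccc2N2CCN(C)CC2)CC1c1ccccc1`: 3.97
Compound 3 `COC(=O)C1C(=O)C=C(Nc2ccc(N3CCN(C)CC3)cc2)CC1C`: 2.7

In a physicochemical assay for lipophilicity (a higher number here means a more lipophilic compound, a lower number a more polar compound), compound 1 gives the highest of the three numbers. Compound 2 comes nearest, with a value beyond the scatter below it, and compound 3 lies furthest away.

Compound 4 `COC(=O)C1C(=O)C=C(Nc2cccc(N3CCN(C)CC3)c2)CC1c1ccccc1` is not yet measured. It differs from compound 1 in one place: hydrogen in place of methyl on a saturated chain carbon bound to an oxygen next to a carbonyl group. The change removes one carbon from the ester chain and nothing else.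

Because compound 1 gives 4.37, and since a change of this size tends to lower a partition coefficient a little, the step from compound 1 to compound 4 is expected to be small and downward, near the edge of the scatter. Compound 4 is therefore estimated at 3.95, in the range 3.6 to 4.3, a step of a number 0.42 log units lower from compound 1 to compound 4 (beyond the scatter) from compound 1.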

Compound 4, partition coefficient: 3.99
Compound 4: middle estimate off by 0.04 log units, on the low side, and the stated range covers the measured number.
By their numbers in this assay, from the lowest: compound 3; then compounds 2 and 4 (each within the scatter of the next); then compound 1.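

In this assay, for the compounds shown here, the step from ethyl to methyl on the ester chain is a number 0.38 log units lower from compound 1 to compound 4 (beyond the scatter) and is the first comparison here in which only one place changes. It shows that removing this one carbon, with the rest of compound 1 kept, moves the number by a measurable amount. Nothing measured here explains the size of this step.

On these data alone, a longer chain such as propyl, or a carboxylic acid in place of the ester, remains open. So does whether the same step would appear on another core.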